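The source may report more compounds than this note shows. Statements on the series, on what has been measured and on what is new or still open speak of the compounds shown alone.

Working notes on the series. Of the compounds shown here, three have been measured in an assay on isolated protein for inhibition of aldehyde dehydrogenase 1A1 (Homo sapiens), read by spectrophotometry, tested at 10 uM; on this read-out lower numbers stand for less inhibition and higher numbers for more inhibition at the one concentration tested (going by the name of the read-out). Compound 1 `COc1cccc(Cn2c(CN3CCN(C(=O)C4CC4)CC3)nc3ccccc32)c1` gives 44.4% in this assay. Compound 2 `Cc1cccc(Cn2c(CN3CCN(C(=O)c4ccc(C#N)cc4)CC3)nc3ccccc32)c1` gives 20.8%, and compound 3 `CC(C)CCn1c(OC2CCN(C(=O)C3CC3)CC2)nc2ccccc21` gives 56.4%. On these numbers compound 1 stands second highest of the three: its nearest neighbour is compound 3, which sits higher by a gap beyond the scatter, and its furthest is compound 2, which sits lower, also beyond the scatter.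

Compound 4 `CCCCn1c(CN2CCN(C(=O)C3CC3)CC2)nc2ccccc21` is not yet measured. Relative to compound 1 the change is propyl in place of 3-methoxyphenyl on a saturated chain carbon bound to an aromatic nitrogen. Within the data shown here, no step between two measured compounds isolates this change, so its size cannot be read off any measured pair. Compound 3, which also carries a saturated chain on the aromatic nitrogen, gives 56.4%, but it differs from compound 1 in more than one place and supports only a loose reading. The expected step of a number 2.4 percentage points lower from compound 1 to compound 4 (within the scatter) is therefore small, downward if anything, and may well fall within the scatter. Compound 4 is estimated at about 42%, with a range from 25% to 60%.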

Compound 4, a percentage reported as inhibition, at one concentration (the size of the read-out at that concentration, not a potency): 18.2%
Compound 4: the middle estimate sits 23.8 percentage points above what was measured; measured number below the stated range.
By their numbers in this assay, from the lowest: compounds 4 and 2 (each within the scatter of the next); then compound 1; then compound 3.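

Propyl in place of 3-methoxyphenyl on a saturated chain carbon bound to an aromatic nitrogen gives the first step in the series that isolates a single place: in this assay it is a number 26.2 percentage points lower from compound 1 to compound 4 (beyond the scatter) and is the only direct reading of this position. Among these compounds, with the rest of compound 1 held fixed, what this position carries clearly matters, and here the 3-methoxybenzyl group goes with more inhibition at the one concentration tested than the butyl group, which the earlier compounds, all differing from one another in more than one place, could not show. No independent measurement on these compounds bears on the reason for the size of this step.

The change removes the aromatic ring and the methoxy group together, so the compounds shown leave open which of the two accounts for the step, and an unsubstituted benzyl group at this place would separate them. Also open, as far as these compounds go, is whether a saturated ring such as cyclohexylmethyl, or a longer chain such as hexyl, would read closer to compound 1 or to compound 4 on this position.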